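Adding a Third Methoxy Group to a Growth Inhibitor

A few compounds are considered here, and "the series" means these few. Any claim that something is new, unique, unknown or untested is made for them only; others in the source may bear on it.

Compound 1 `COc1ccc(/C=C/C2CC(=O)C=CO2)cc1` and compound 2 `COc1ccc(/C=C/C2CC(=O)C=CO2)cc1OC` share one core and differ in a single place: methoxy in place of hydrogen on an aromatic carbon. In a functional assay on HT-29 cells (Homo sapiens) for inhibition, read by sulforhodamine B assay, with a stated time of 48 h (a higher number here means a weaker inhibitor of growth, a lower number a stronger inhibitor of growth), compound 1 gives 204 uM, while compound 2 gives 123 uM. Between them there is a 1.7-fold lower number from compound 1 to compound 2 (0.22 log units; within the scatter), so the two numbers cannot be told apart with confidence.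

Compound 3 `COc1cc(/C=C/C2CC=CC(=O)O2)cc(OC)c1` is built on a different core; the difference between the two cores is not broken down here. In this assay compound 3 gives 8.2 uM, the lowest of the three numbers, and its gaps to compound 2 and to compound 1 both lie beyond the scatter.

Compound 4 `COc1cc(/C=C/C2CC=CC(=O)O2)cc(OC)c1OC` has not yet been measured. It differs from compound 3 by methoxy in place of hydrogen on an aromatic carbon. Among the measured compounds shown here, this is the same kind of change as the one from compound 1 to compound 2, but not the same change: in compound 2 the entering group sits ortho to a methoxy group and meta to a group of 9 heavy atoms, whereas in compound 4 it sits ortho to two methoxy groups and para to a group of 9 heavy atoms.

For the measured compounds named here, the only comparable precedent is the pair on the other core, where the change produced a 1.7-fold lower number from compound 1 to compound 2 (0.22 log units; within the scatter). On that basis the expected step for compound 4 in this assay is a 1.3-fold lower number from compound 3 to compound 4 (0.10 log units; within the scatter), a small one. Compound 4 is therefore estimated at 6.5 uM, with a likely range from 2.5 uM to 18 uM.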

Compound 4, concentration for growth inhibition (reported as GI): 18.8 uM
Compound 4: the middle estimate sits 2.9-fold (0.46 log units) below what was measured; measured number above the stated range.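

In this assay, methoxy in place of hydrogen on an aromatic carbon, here ortho to two methoxy groups and para to a group of 9 heavy atoms, gives a 2.3-fold higher number from compound 3 to compound 4 (0.36 log units; beyond the scatter), so this addition goes with a modest weakening of growth inhibition on this core. Set beside the earlier pair, the change does not carry over unaltered from one core to the other in this series: the same change on two cores in this assay, a 1.7-fold lower number (0.22 log units; within the scatter) from compound 1 to compound 2 and a 2.3-fold higher number (0.36 log units; beyond the scatter) from compound 3 to compound 4, 3.8-fold (0.58 log units) apart, beyond the scatter of two such steps. This does not show that the core alone decides the outcome, since the entering methoxy also occupies a different place on the aromatic ring in the two pairs, and with a single pair on each core the data cannot separate these two differences or give a general rule for either core.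

The compounds shown leave open how a third methoxy group would behave on the core of compound 1, and whether the effect on the core of compound 3 depends on where the methoxy group enters. They also leave open whether a hydroxyl group, a fluorine atom or a longer chain such as ethoxy at the same place would follow compound 4 or stay level with compound 3.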